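Acylurea series: aryl change on the carbonyl of compound 1

The source may report more compounds than this note shows. Statements on the series, on what has been measured and on what is new or still open speak of the compounds shown alone.

For the measured compounds named here, compound 1 `CN(C(=O)NC(=O)c1ccccc1F)c1nc(C(F)(F)F)c(C(=O)N/N=C/c2cc(C(F)(F)F)cc(C(F)(F)F)c2)s1` is the only member of the series with a number in a functional assay on BCG823 cells (Homo sapiens) for inhibition, read by MTT assay, with a stated time of 72 h; on this read-out lower numbers stand for stronger inhibition and higher numbers for weaker inhibition: compound 1 gives 4.23 ug/mL. Compound 2 `CNc1nc(C(F)(F)F)c(C(=O)N/N=C/c2cc(C(F)(F)F)cc(C(F)(F)F)c2)s1`, which carries hydrogen in place of ((2-fluorophenyl)carbonyl)carbamoyl on a nitrogen on an aromatic ring, reaches only a limit; in this assay compound 2 gives > 100 ug/mL. The one measured step is therefore an at least 23-fold higher number from compound 1 to compound 2 (1.37 log units; beyond the scatter), and it tells only that the whole acylcarbamoyl arm is needed for the inhibition seen in compound 1, as shown by the limit of > 100 ug/mL in this assay, at which 1 of the 2 values shown sits.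

Compound 3 `CN(C(=O)NC(=O)c1ccc(C(F)(F)F)cc1)c1nc(C(F)(F)F)c(C(=O)N/N=C/c2cc(C(F)(F)F)cc(C(F)(F)F)c2)s1` keeps that arm intact and changes it at its far end: 4-(trifluoromethyl)phenyl in place of 2-fluorophenyl on a carbonyl carbon. Going by the values given here, no measured step speaks to a swap of one aryl group for another on this carbonyl carbon, so the step from compound 1 to compound 2 gives no direction for it. The expectation for compound 3 is a step in this assay of a 1.1-fold higher number from compound 1 to compound 3 (0.03 log units; within the scatter), not beyond the scatter. Compound 3 is estimated at 4.5 ug/mL, within 1.5 ug/mL to 15 ug/mL.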

Compound 3, half-maximal inhibitory concentration: 1.77 ug/mL
Estimate against measurement, compound 3: 2.5-fold (0.41 log units) above; measured number inside the range.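

Within the acylcarbamoyl arm, the aryl group on the carbonyl carbon is a position where the number can be moved: in this assay, 4-(trifluoromethyl)phenyl in place of 2-fluorophenyl gives a 2.4-fold lower number from compound 1 to compound 3 (0.38 log units; beyond the scatter). The earlier pair showed only the effect of removing the whole arm, whereas this step shows that a change at its far end, with the arm otherwise intact, also registers beyond the scatter and that the larger aryl group is accepted here without loss of inhibition. Nothing shown gives a reason for this step.

The two aryl groups differ both in the substituent on the ring and in its place, so the compounds shown do not separate these two changes, and 4-fluorophenyl or 2-(trifluoromethyl)phenyl on the same carbonyl carbon would be the compounds to do so. Also open, as far as these compounds go, is whether this carbonyl carbon needs an aryl group at all, which cyclohexyl or a short alkyl chain there would test, and how a ring carrying an amine or a carboxylic acid would read in this assay.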